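The source may report more compounds than this note shows. Statements on the series, on what has been measured and on what is new or still open speak of the compounds shown alone.

Working notes on the series, followed in a functional assay on HeLa cells (Homo sapiens) for inhibition, read by CCK-8 assay, with a stated time of 48 h; on this read-out lower numbers stand for stronger inhibition and higher numbers for weaker inhibition. Compound 1 (`C#CCOc1ccc(C(=O)/C=C/c2ccccc2)cc1`) gives > 50000 nM as a limit of the assay and not a number. Compound 2 (`C#CCOc1ccc(C(=O)/C=C/c2ccc(Cl)c(Cl)c2)cc1`) gives > 50000 nM as a limit too, so its position is bounded and has no number. Compound 3 (`C#CCOc1ccc(C(=O)/C=C/c2cccc(Cl)c2)c(O)c1`) gives > 50000 nM as a further limit. The whole set reads the same way: the limit of > 50000 nM in this assay, at which 3 of the 3 values shown sit. Going by the values given here, no pair of measured compounds differs in one place alone, so the series offers no measured step to scale from.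

The next compound is compound 4 (`C#CCOc1ccc(C(=O)/C=C/c2ccc(Cl)c(Cl)c2)c(O)c1`), which keeps the dichloro substitution of compound 2 and changes one thing: hydroxy in place of hydrogen on an aromatic carbon. The hydroxy sits on an aromatic carbon, ortho to a large group and meta to a propargyloxy group.

The hydroxy alone gives no sign of a gain, since compound 3 carries it and still gives > 50000 nM as a limit. Only a small step towards stronger inhibition is therefore expected, and a reading that again stays at the limit is quite possible. The expected change is an at least 1.2-fold lower number from compound 2 to compound 4 (0.09 log units; that floor lies within the scatter) on this estimate. For compound 4 the estimated value is 40000 nM with an expected range from 12000 nM to 80000 nM in this assay.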

Compound 4, half-maximal inhibitory concentration: > 50000 nM
Compound 4: no number, only a limit; the forecaster's own chance of this, stated with the estimate: 55%; at least 1.2-fold (0.09 log units) between middle value and limit.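

In this assay compound 4 gives > 50000 nM, a limit of the assay and not a number. No new step can be read from compound 2 or compound 3 to compound 4, as all these values are limits: the limit of > 50000 nM in this assay, at which 4 of the 4 values shown sit. The compounds shown leave open whether the hydroxy or the added chloro changes inhibition at all.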